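A Benzamide in Place of the Urea: Compound 4

The compounds below may be only part of what the source reports. "The series", "measured", "known", "first", "only" and "open" are said of these compounds alone.

Three compounds have been measured in a functional assay on MDA-MB-435 cells (Homo sapiens) for inhibition, read by sulforhodamine B assay, with a stated time of 48 h; a higher number here means a weaker inhibitor of growth, a lower number a stronger inhibitor of growth:

Compound 1 `COc1cc(-c2nn(-c3cccc(NC(=O)Nc4ccc(Cl)c(Cl)c4)c3)cc2-c2ccncc2)ccc1Cl` gives 938 nM.
Compound 2 `O=C(Nc1cccc(-n2cc(-c3ccncc3)c(-c3ccc(Cl)c(O)c3)n2)c1)Nc1ccc(Cl)c(Cl)c1` gives 1100 nM.
Compound 3 `O=C(Nc1cccc(-n2cc(-c3ccncc3)c(-c3ccc(Cl)c(O)c3)n2)c1)Nc1cc(C(F)(F)F)cc(C(F)(F)F)c1` gives 910 nM.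

Compound 1 stands second highest of the three, and all three lie within the scatter of one another: the nearest is compound 3 and the furthest compound 2, so no order among them can be claimed. Compound 4 `COc1cc(-c2nn(-c3cccc(NC(=O)c4ccccc4)c3)cc2-c2ccncc2)ccc1Cl` differs from compound 1 by phenyl in place of (3,4-dichlorophenyl)amino on a carbonyl carbon; cut one bond further out, this reads ((3,4-dichlorophenyl)carbamoyl)amino to benzamido. Going by the values given here, only one measured step exists, a 1.2-fold higher number from compound 1 to compound 2 (0.07 log units; within the scatter), and it concerns the oxygen on the aromatic ring, not the carbonyl. Compounds 2 and 3 differ in the aryl attached through the amino group, and their values are close, but neither touches the amino link itself. Among the compounds with values here, no measured step therefore bears directly on this change. Compound 4 is expected to give a higher number, a step of about a 3.2-fold higher number from compound 1 to compound 4 (0.50 log units; beyond the scatter), with an estimate of 3000 nM in a range from 900 nM to 10000 nM.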

Compound 4, concentration for 50% growth inhibition: 189 nM
Compound 4: the middle estimate sits 16-fold (1.20 log units) above what was measured; measured number outside the range, below it.
By their numbers in this assay, from the lowest: compound 4; then compounds 3, 1 and 2 (each within the scatter of the next).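

Compound 4 gives the first step among these compounds that lies beyond the scatter in this assay: a 5.0-fold lower number from compound 1 to compound 4 (0.70 log units; beyond the scatter), with the change made on the carbonyl carbon. The earlier compounds shown here varied only the oxygen on the aromatic ring or the outer aryl group, whereas this result shows that the urea with its (3,4-dichlorophenyl)amino group is not required for growth inhibition at this level. No measurement shown explains the lower number.

The change removes the amino nitrogen and both chlorines together, so the compounds shown cannot separate their contributions. A 3,4-dichlorophenyl group on the same carbonyl carbon would address this, while a methyl or cyclohexyl group there would test whether the aromatic ring itself matters.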